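A second 2-hydroxyethyl on compound 1

A few compounds are considered here, and "the series" means these few. Any claim that something is new, unique, unknown or untested is made for them only; others in the source may bear on it.

Compound 1 (`COc1cc(NC(C)CCCNC(=O)NCCO)c2ncccc2c1`) was examined in a functional assay on NCI-H460 cells (Homo sapiens); a lower number here means a stronger inhibitor, a higher number a weaker inhibitor. Compound 1 gives > 100000 nM as a limit of the assay, not as a number. Its close relative compound 2 (`COc1cc(NC(C)CCCNC(=O)NCCCO)c2ncccc2c1`) also gives > 100000 nM as a limit of the assay. All the readings so far thus rest on (the limit of > 100000 nM in this assay, at which 2 of the 2 values shown sit), and no true number is known for compound 1.

Compound 3 (`COc1cc(NC(C)CCCNC(=O)N(CCO)CCO)c2ncccc2c1`) comes from compound 1 by a single change: 2-hydroxyethyl in place of hydrogen on an amide-type nitrogen. In words, 2-hydroxyethyl takes the place of hydrogen on an amide-type nitrogen, so that (2-hydroxyethyl)amino becomes bis(2-hydroxyethyl)amino.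

For the measured compounds named here, only one measured step bears on this change, and it is a step that the two limits leave unreadable from compound 1 to compound 2. It offers no size to carry forward and no direction, so the expectation in this assay is that compound 3 stays at the same limit, with no shift that can be read. The expected step is a number no higher from compound 1 to compound 3 (the limit leaves the size open). The estimate for compound 3 is 100000 nM, with an expected range from 30000 nM to 200000 nM.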

Compound 3, half-maximal inhibitory concentration: > 100000 nM
Compound 3: only a limit was reported; the forecaster's own chance of this, stated with the estimate: 85%; the middle value sits exactly at the limit.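

In this assay compound 3 gives > 100000 nM, a limit of the assay and not a number. No step can be read from compound 1 or compound 2 to compound 3, as all the readings rest on one limit: the limit of > 100000 nM in this assay, at which 3 of the 3 values shown sit.

The compounds shown leave open what true value any of the three has, and whether 2-hydroxyethyl in place of hydrogen on the amide-type nitrogen shifts it at all.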